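The source may hold more compounds than are shown below. What is called first, only, known or untested is meant among the compounds shown, and "the series" means these compounds.

For the measured compounds named here, in a functional assay on HepG2 cells (Homo sapiens) for inhibition, read by MTT assay (a higher number here means a weaker inhibitor of growth, a lower number a stronger inhibitor of growth), three compounds sharing one core have numbers so far: compound 1 (`COc1cc2oc(-c3cccc(NC(=O)c4cccc(Br)c4)c3)cc(=O)c2c(OC)c1OC`) gives 10900 nM, compound 2 (`COc1cc2oc(-c3cccc(NC(=O)c4ccccc4Br)c3)cc(=O)c2c(OC)c1OC`) gives 23100 nM, and compound 3 (`COc1cc2oc(-c3cccc(NC(=O)c4ccc(Cl)cc4)c3)cc(=O)c2c(OC)c1OC`) gives 21300 nM. Compound 3 cannot be told apart from either of the others, since a 1.1-fold lower number from compound 2 to compound 3 (0.04 log units; within the scatter) and a 2.0-fold higher number from compound 1 to compound 3 (0.29 log units; within the scatter). Only a 2.1-fold higher number from compound 1 to compound 2 (0.33 log units; beyond the scatter) passes beyond the scatter, and only modestly. Compound 4 (`COc1cc2oc(-c3cccc(NC(=O)c4ccc(C#N)cc4)c3)cc(=O)c2c(OC)c1OC`) keeps the core and the amide of compound 3 and alters one group: cyano in place of chloro on an aromatic carbon. This is cyano in place of chloro on an aromatic carbon, para to a large group. Going by the values given here, no measured compound carries a cyano group, so the only guide is the three steps among the halogenated phenyl groups on the carbonyl carbon. Since the largest of them is a 2.1-fold higher number from compound 1 to compound 2 (0.33 log units; beyond the scatter), no step beyond the scatter is expected in this assay. The estimated change is a 1.1-fold lower number from compound 3 to compound 4 (0.03 log units; within the scatter). Compound 4 is expected at about 20000 nM, within an estimated range of 9000 nM to 45000 nM.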

Compound 4, concentration for 50% growth inhibition: 10200 nM
Estimate against measurement, compound 4: 2.0-fold (0.29 log units) above, and the stated range covers the measured number.
By their numbers in this assay, from the lowest: compounds 4, 1, 3 and 2 (each within the scatter of the next, the first and the last beyond it).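

In this assay the change from chloro to cyano on this aromatic carbon gives a step beyond the scatter (a 2.1-fold lower number from compound 3 to compound 4 (0.32 log units; beyond the scatter)), and it is the first pair shown to differ at this carbon alone, so the group held here can shift the number, if only modestly. The 4-cyanophenyl amide also stands apart from the 2-bromophenyl amide (a 2.3-fold lower number from compound 2 to compound 4 (0.36 log units; beyond the scatter)), but it cannot be told apart from the 3-bromophenyl amide (a 1.1-fold lower number from compound 1 to compound 4 (0.03 log units; within the scatter)), so a cyano group at this carbon and a bromo group on a different ring carbon give matching numbers. Nothing shown accounts for the step between chloro and cyano.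

The compounds shown leave open how an amine, a carboxylic acid or a methoxy group on this carbon would compare. Going by these compounds, it also remains open whether cyano would give a similar step on another carbon of this ring.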